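The source may hold more compounds than are shown below. What is called first, only, known or untested is meant among the compounds shown, and "the series" means these compounds.

In a functional assay on Caco-2 cells (Homo sapiens) for antiproliferative activity, read by MTT assay, with a stated time of 48 h (on this read-out higher numbers stand for weaker inhibition and lower numbers for stronger inhibition), compound 1 `CCN(CC)CCNC(=O)c1ccc(C(CC)(CC)c2ccc(OCCC(O)(CC)CC)c(C)c2)n1CC` gives 1630 nM. Compound 2 `CCn1c(C(=O)Nc2ccc(OC(F)(F)F)cc2)ccc1C(CC)(CC)c1ccc(OCCC(O)(CC)CC)c(C)c1` gives > 50000 nM, which is a limit and not a number. Compound 3 `CCOc1ccc(NC(=O)c2ccc(C(CC)(CC)c3ccc(OCCC(O)(CC)CC)c(C)c3)n2CC)cc1` gives > 50000 nM, which is also a limit and not a number. On these data alone, compound 3 therefore stands at the limit of > 50000 nM in this assay, at which 2 of the 3 values shown sit, so its true position is unknown.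

The next compound is compound 4 `CCOC(=O)C(CC(=O)OC)NC(=O)c1ccc(C(CC)(CC)c2ccc(OCCC(O)(CC)CC)c(C)c2)n1CC`. It changes the group on the amide-type nitrogen: a group of 11 heavy atoms (7 carbon, 4 oxygen; no ring) in place of a group of 9 heavy atoms (8 carbon, 1 oxygen; one six-membered aromatic ring of carbon only), on an amide-type nitrogen. Within the data shown here, two measured steps bear on this place. They are an at least 30-fold higher number from compound 1 to compound 2 (1.48 log units; beyond the scatter) and an at least 30-fold higher number from compound 1 to compound 3 (1.48 log units; beyond the scatter), both large, and in both a substituted phenyl group stands in place of 2-(diethylamino)ethyl. The third step, a step that the two limits leave unreadable from compound 2 to compound 3, shows nothing about size. Among the measured compounds shown here, compound 4 has no ring in the new group, like compound 1, but it does not carry the 2-(diethylamino)ethyl group of compound 1, the only compound here with a measured number, at 1630 nM. A large gain is therefore not expected in this assay, only a modest move toward a lower number, and a second limit is quite possible.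

The expected size of the change is an at least 1.2-fold lower number from compound 3 to compound 4 (0.09 log units; that floor lies within the scatter). For compound 4 the estimated value is 40000 nM, with an expected range from 10000 nM to 100000 nM.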

Compound 4, half-maximal inhibitory concentration: 3020 nM
Compound 4: the middle estimate sits 13-fold (1.12 log units) above what was measured; the whole stated range lies above it.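

Among these compounds, compound 4 shows that the 2-(diethylamino)ethyl group is not the only group on this amide-type nitrogen that gives a readable number in this assay. Its ring-free group holds no nitrogen, yet the two compounds cannot be told apart, with a 1.9-fold higher number from compound 1 to compound 4 (0.27 log units; within the scatter). Against the two substituted phenyl amides the change is large, with an at least 16-fold lower number from compound 3 to compound 4 (1.21 log units; beyond the scatter) and an at least 16-fold lower number from compound 2 to compound 4 (1.21 log units; beyond the scatter), and among these four compounds both ring-free groups give a number while compounds 2 and 3 give only a limit, so those two steps are floors and not exact sizes: the limit of > 50000 nM in this assay, at which 2 of the 4 values shown sit.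

On these data alone, what stays open is which part of the new group carries the result, since compound 4 differs from compound 1 by the whole group and its two ester groups are never varied apart. A carboxylic acid in place of either ester, a plain alkyl chain with no ester, or a phenyl ring bearing an amine would show whether the ring itself or the substituents on it separate compounds 2 and 3 from compounds 1 and 4.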